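This account rests on a few compounds, and the source may have more. Where it says the series, first, only, none or still open, it means among the compounds named here.

Measured so far in a functional assay on HCT-116 cells (Homo sapiens); on this read-out lower numbers stand for higher toxicity in this test and higher numbers for lower toxicity in this test:
Compound 1 `O=C1C=CC(O)(c2cc3ccccc3n2S(=O)(=O)c2ccccc2)C=C1` gives 116000 nM.
Compound 3 `O=C1C=CC(O)(c2cc3cc(F)ccc3n2S(=O)(=O)c2ccccc2)C=C1` gives 50 nM.
Compound 2 `O=C1C=CC(O)(c2cc3ccc(F)cc3n2S(=O)(=O)c2ccccc2)C=C1` gives a limit of the assay, < 10 nM.

Compound 1 stands highest of the two numbers shown; the step to the nearest number reads a 2300-fold lower number from compound 1 to compound 3 (3.37 log units; beyond the scatter).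

Compound 4 `O=C1C=CC(O)(c2cc3ccccc3n2S(=O)(=O)c2ccc(F)cc2)C=C1` differs from compound 1 by fluoro in place of hydrogen on an aromatic carbon. Both measured steps, an at least 11000-fold lower number from compound 1 to compound 2 (4.06 log units; beyond the scatter) and a 2300-fold lower number from compound 1 to compound 3 (3.37 log units; beyond the scatter), set the fluorine elsewhere on the shared core, not on the six-membered aromatic ring of carbon only where compound 4 carries it; one of them ends at the limit of < 10 nM in this assay, at which 1 of the 3 values shown sits. They show fluorine lowering the number strongly, but at a different place, so a smaller step is expected here: a 12-fold lower number from compound 1 to compound 4 (1.06 log units; beyond the scatter). Compound 4 is therefore estimated at 10000 nM, with a range of 800 nM to 120000 nM.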

Compound 4, concentration lethal to 50% of the cells: 360 nM
Compound 4: the middle estimate sits 28-fold (1.44 log units) above what was measured; the whole stated range lies above it.
By their numbers in this assay, from the lowest: compound 3; then compound 4; then compound 1. At a limit, below all of these: compound 2.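

In this assay, phenyl to 4-fluorophenyl gives a 320-fold lower number from compound 1 to compound 4 (2.51 log units; beyond the scatter), so the lowering seen with fluoro on the shared core also occurs on the six-membered aromatic ring of carbon only. All three single fluoro changes from compound 1 now lower the number beyond the scatter, and none of the compounds shown goes against this. Nothing given here accounts for the size of this step.

As far as these compounds go, whether this position is specific to fluoro stays open, since chloro, methoxy or an amine in its place would be needed to tell. Also open, from the compounds shown here alone, is how fluoro at this position combines with fluoro on the shared core.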